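The compounds below may be only part of what the source reports. "The series", "measured", "known", "first", "only" and "open" are said of these compounds alone.

Of the compounds shown here, three sharing one core have been measured in an assay on isolated protein for inhibition of Indoleamine 2,3-dioxygenase 2 (Homo sapiens); on this read-out higher numbers stand for weaker inhibition and lower numbers for stronger inhibition. Compound 1 `OCCc1cn(CCNc2nonc2/C(=N/O)Nc2ccc(F)c(Br)c2)nn1` gives 1170 nM, compound 2 `OCCCCc1cn(CCNc2nonc2/C(=N/O)Nc2ccc(F)c(Br)c2)nn1` gives 1080 nM, and compound 3 `CC(O)c1cn(CCNc2nonc2/C(=N/O)Nc2ccc(F)c(Br)c2)nn1` gives 362 nM. Compound 2 therefore stands second highest of the three, close to compound 1 and well apart from compound 3. Compound 4 `OCCOCc1cn(CCNc2nonc2/C(=N/O)Nc2ccc(F)c(Br)c2)nn1` is not yet measured; it differs from compound 2 by 2-hydroxyethoxy in place of 3-hydroxypropyl on a saturated chain carbon bound to an aromatic carbon. The step that bears on this is a 1.1-fold lower number from compound 1 to compound 2 (0.03 log units; within the scatter), where lengthening the hydroxyalkyl chain changed nothing beyond the scatter; compound 4 keeps a chain of similar reach, going from 4-hydroxybutyl to (2-hydroxyethoxy)methyl. Compound 4 is therefore expected to move only a 1.1-fold lower number from compound 2 to compound 4 (0.03 log units; within the scatter), within the scatter. The estimate for compound 4 is 1000 nM, ranging from 450 nM to 2300 nM.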

Compound 4, half-maximal inhibitory concentration: 144 nM
For compound 4 the middle estimate is 6.9-fold (0.84 log units) above the measured one; measured number outside the range, below it.
By their numbers in this assay, from the lowest: compound 4; then compound 3; then compounds 2 and 1 (each within the scatter of the next).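

Replacing one chain carbon with oxygen, 3-hydroxypropyl to 2-hydroxyethoxy, gives a 7.5-fold lower number from compound 2 to compound 4 (0.88 log units; beyond the scatter) in this assay, so at this position the makeup of the chain matters, not just its reach. Compound 4 also improves on the other two, with an 8.1-fold lower number from compound 1 to compound 4 (0.91 log units; beyond the scatter) and a 2.5-fold lower number from compound 3 to compound 4 (0.40 log units; beyond the scatter), making it the strongest inhibitor of the four. No evidence here explains why this chain does better.

The compounds shown leave open whether the oxygen must sit at this point in the chain and whether the end hydroxy is needed. A methoxy or an amine at the chain end, or a longer chain holding a second ether oxygen, would address both questions.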